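A few compounds are considered here, and "the series" means these few. Any claim that something is new, unique, unknown or untested is made for them only; others in the source may bear on it.

Measured compounds:
Compound 1, `C[C@@H](NC(=O)Nc1ccc(C(C)(C)C)cc1)c1ccccc1`: in an ADME assay on the whole organism with Oryza sativa as the target, tested at 0.1 uM (a lower number here means a stronger effect, a higher number a weaker effect of the compound at the concentration tested), compound 1 gives 100%.
Compound 2, `CCCCCc1ccc(NC(=O)N[C@H](C)c2ccccc2)cc1`: compound 2 gives 100%.
Compound 3, `C[C@@H](NC(=O)Nc1ccc(F)cc1)c1ccccc1`: compound 3 gives 98%.

The three compounds share one core and differ only in the group carried on a single aromatic carbon. Exchanging that group has so far moved nothing: the step of no change at the digits printed from compound 1 to compound 2 (within the scatter), the step of a number 2 percentage points lower from compound 1 to compound 3 (within the scatter) and the step of a number 2 percentage points lower from compound 2 to compound 3 (within the scatter) all stay within the scatter of repeated measurements. Compound 3 therefore stands on one level with compound 1 and compound 2, and no order can be read among the three.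

Compound 4, `C[C@@H](NC(=O)Nc1ccc(Br)cc1)c1ccccc1`, has not yet been measured. It differs from compound 3 by bromo in place of fluoro on an aromatic carbon. For the measured compounds named here, no measured step involves bromo, so the bearing steps are the three exchanges at that same aromatic carbon, which covered tert-butyl, pentyl and fluoro and were all within the scatter. On that basis the step of no change at the digits printed from compound 3 to compound 4 (within the scatter) is expected to stay within the scatter as well, with no direction to it. Compound 4 is accordingly estimated at 98%, with a range from 88% to 100%.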

Compound 4, a percentage reported as activity, at one concentration (the size of the read-out at that concentration, not a potency): 100%
Estimate against measurement, compound 4: 2 percentage points below, and the stated range covers the measured number.
By their numbers in this assay, from the lowest: compounds 3, 1, 2 and 4 (each within the scatter of the next).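

With bromo at this aromatic carbon, the exchange extends to a fourth group and a second halogen, and the level still holds: in this assay, the steps of a number 2 percentage points higher from compound 3 to compound 4 (within the scatter), no change at the digits printed from compound 2 to compound 4 (within the scatter) and no change at the digits printed from compound 1 to compound 4 (within the scatter) all stay within the scatter. Bromo, fluoro, tert-butyl and pentyl, on this carbon para to a large group, therefore cannot be told apart in this read-out, and no order can be read among the four compounds. No supporting evidence is available to explain why these exchanges leave the read-out level.

The compounds shown leave open whether an amine, a carboxylic acid or a hydroxyl group on the same aromatic carbon would stay on this level or produce a step beyond the scatter. They also leave open whether anything outside this one position matters, such as replacing the methyl group of the shared core with a longer chain, since all four compounds differ only at this aromatic carbon.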